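Terminal aryl exchange on the cinnamate ester amide series

A few compounds are considered here, and "the series" means these few. Any claim that something is new, unique, unknown or untested is made for them only; others in the source may bear on it.

Measured compounds in an assay on isolated protein with Bile acid receptor (Homo sapiens) as the target; on this read-out higher numbers stand for an effect only at larger amounts of compound and lower numbers for an effect already at smaller amounts:
compound 1 `COC(=O)/C=C/c1cccc(N(Cc2ccc(-c3cccc(C)c3)cc2)C(=O)C2CCCCC2)c1`: 109 nM
compound 2 `COC(=O)/C=C/c1cccc(N(Cc2ccc(-c3cccc(C)c3)cc2)C(=O)C(C)C)c1`: 163 nM
compound 3 `COC(=O)/C=C/c1cccc(N(Cc2ccc(-c3cccc(C)c3)cc2)C(=O)NC(C)C)c1`: 1330 nM

Compound 1 gives the lowest of the three numbers in this assay. Compound 2 sits close to it, a 1.5-fold higher number from compound 1 to compound 2 (0.17 log units; within the scatter), whereas compound 3 lies well apart, a 12-fold higher number from compound 1 to compound 3 (1.09 log units; beyond the scatter), and the gap between compound 2 and compound 3 is likewise clear, an 8.2-fold higher number from compound 2 to compound 3 (0.91 log units; beyond the scatter).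

Compound 4 `COC(=O)/C=C/c1cccc(N(Cc2ccc(-c3cc(Cl)ccc3OC)cc2)C(=O)C2CCCCC2)c1` differs from compound 1 at the distal ring of the benzyl substituent: 5-chloro-2-methoxyphenyl in place of 3-methylphenyl on an aromatic carbon

All three measured steps concern the group on the carbonyl carbon, not the distal aryl ring, so none of them bears on this change. Nothing in the measured set shows how this assay responds to a substituent exchange on that ring, and no step beyond the scatter is expected in either direction; the uncertainty is correspondingly wider than the scatter alone. Compound 4 is therefore expected to give 120 nM (range 40 nM to 400 nM), which corresponds to an expected step of a 1.1-fold higher number from compound 1 to compound 4 (0.04 log units; within the scatter).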

Compound 4, half-maximal effective concentration: 233 nM
Compound 4: the middle estimate sits 1.9-fold (0.29 log units) below what was measured; the range from low to high includes it.
By their numbers in this assay, from the lowest: compounds 1, 2 and 4 (each within the scatter of the next, the first and the last beyond it); then compound 3.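

In this assay, the distal ring of the benzyl substituent proves responsive to substitution: 5-chloro-2-methoxyphenyl in place of 3-methylphenyl gives a 2.1-fold higher number from compound 1 to compound 4 (0.33 log units; beyond the scatter), a modest step that lies just beyond the scatter. This exchange adds heavy atoms and a hydrogen-bond acceptor, yet the shift is smaller than that seen on the carbonyl side, a 12-fold higher number from compound 1 to compound 3 (1.09 log units; beyond the scatter). No available evidence bears on the origin of this shift.

The chloro and methoxy groups enter together, so their separate contributions remain unresolved, as does the effect of this exchange alongside the isopropyl group of compound 2. Also open, as far as these compounds go, is how this assay would respond to a carboxylic acid or a dimethylamino group on the distal ring.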